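The source may hold more compounds than are shown below. What is called first, only, known or untested is meant among the compounds shown, and "the series" means these compounds.

Of the compounds shown here, three have so far been measured in a physicochemical assay for lipophilicity, read by HPLC, at pH 7.4; on this read-out lower numbers stand for lower lipophilicity and higher numbers for higher lipophilicity. Compound 1 `C[C@@H](Oc1cc2sc(=O)n(CCC(=O)O)c2cc1Cl)c1ccccn1` gives 1.81, compound 2 `C[C@@H](Oc1cc2c(cc1Cl)N(CCC(=O)O)C(=O)CO2)c1ccccn1` gives 1.56, and compound 3 `CCc1cc2oc(=O)n(CCC(=O)O)c2cc1Cl` gives 1.94. Compound 3 has the highest of the three numbers, though its gap to compound 1 lies within the usual scatter, while its gap to compound 2 lies beyond it. The next compound, compound 4 `O=C(O)CCn1c(=O)oc2cc(Cl)c(Cl)cc21`, has not yet been measured. It differs from compound 3 in a single place: chloro in place of ethyl on an aromatic carbon. Going by the values given here, no pair of measured compounds shows this same exchange, so the size of the step has to be judged from the structures alone. A small fall in this assay, close to the edge of the scatter, is expected, which would mean a step of a number 0.24 log units lower from compound 3 to compound 4 (within the scatter). Compound 4 is therefore estimated at 1.7, most likely between 1.4 and 2.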

Compound 4, distribution coefficient: 1.61
Compound 4: the middle estimate sits 0.09 log units above what was measured, and the stated range covers the measured number.
By their numbers in this assay, from the lowest: compounds 2, 4, 1 and 3 (each within the scatter of the next, the first and the last beyond it).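

On the aromatic carbon ortho to a chloro group, chloro in place of ethyl gives a number 0.33 log units lower from compound 3 to compound 4 (beyond the scatter) in this assay. Going by these compounds alone, this is the first single-place exchange in the set, and it shows that this position can move the read-out even though neither group carries hydrogen-bond donors, hydrogen-bond acceptors or net charge. Nothing available explains the size of this step. On these data alone, whether the same exchange gives a similar step on the other cores remains open. As far as these compounds go, how a methoxy group, an amine or a longer chain such as propyl would read at this position is also open.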